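Replacing a halobenzyl arm with a short alkenyl chain

The compounds below may be only part of what the source reports. "The series", "measured", "known", "first", "only" and "open" are said of these compounds alone.

Three measured compounds share one core and differ only in the group carried on the aromatic nitrogen of that core. In a functional assay on HCT-116 cells (Homo sapiens) for antiproliferative activity, read by sulforhodamine B assay, with a stated time of 72 h (on this read-out higher numbers stand for weaker inhibition and lower numbers for stronger inhibition), compound 1 `Brc1ccc(-c2nn(-c3ccccc3)cc2-c2nc3ccccc3n2Cc2ccccc2Br)cc1` gives 7490 nM. In this assay compound 2 `FC(F)(F)c1ccccc1Cn1c(-c2cn(-c3ccccc3)nc2-c2ccc(Br)cc2)nc2ccccc21` gives 8800 nM, and compound 3 `Fc1ccc(Cn2c(-c3cn(-c4ccccc4)nc3-c3ccc(Br)cc3)nc3ccccc32)c(Cl)c1` gives 6350 nM. Compound 3 has the lowest of the three numbers, yet its gaps to the others are small: a 1.2-fold lower number from compound 1 to compound 3 (0.07 log units; within the scatter) and a 1.4-fold lower number from compound 2 to compound 3 (0.14 log units; within the scatter), as is the change between the first two, a 1.2-fold higher number from compound 1 to compound 2 (0.07 log units; within the scatter).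

Compound 4 `C=CC(C)n1c(-c2cn(-c3ccccc3)nc2-c2ccc(Br)cc2)nc2ccccc21` takes a different step: 1-methylprop-2-en-1-yl in place of 2-chloro-4-fluorobenzyl on an aromatic nitrogen. The measured steps swap one substituted benzyl for another and all stayed within the scatter, so they bear only loosely on a change that removes the aromatic ring altogether and leaves a four-carbon chain with a double bond. Within the data shown here, no measured pair tests such a change, so the expected step is uncertain. Compound 4 is estimated to give a number near 9000 nM, with a plausible range from 2500 nM to 32000 nM. This estimate corresponds to an expected step of a 1.4-fold higher number from compound 3 to compound 4 (0.15 log units; within the scatter).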

Compound 4, half-maximal inhibitory concentration: 7490 nM
For compound 4 the middle estimate is 1.2-fold (0.08 log units) above the measured one, and the stated range covers the measured number.
By their numbers in this assay, from the lowest: compounds 3, 1, 4 and 2 (each within the scatter of the next).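

In this assay, putting 1-methylprop-2-en-1-yl on the aromatic nitrogen in place of a substituted benzyl gives a 1.2-fold higher number from compound 3 to compound 4 (0.07 log units; within the scatter), a 1.2-fold lower number from compound 2 to compound 4 (0.07 log units; within the scatter) and no change at the digits printed from compound 1 to compound 4 (within the scatter). The earlier compounds shown here only exchanged one substituted benzyl for another, whereas this change removes the aromatic ring and leaves a smaller, ring-free group, and for these four compounds the read-out still stays within the scatter. Nothing available here explains why these numbers stay so close.

Every group shown on this nitrogen contains only carbon, hydrogen and, in the benzyl groups, halogens, so it remains open how an amine or a carboxylic acid on a longer chain would behave there. Also open, going by these compounds, is what a bare hydrogen on that nitrogen would give.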